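This account rests on a few compounds, and the source may have more. Where it says the series, first, only, none or still open, it means among the compounds named here.

In a functional assay on Ehrlich cells (Mus musculus) for antiproliferative activity, read by trypan blue exclusion, with a stated time of 2 h, tested at 10 ug/mL (a lower number here means a weaker effect, a higher number a stronger effect of the compound at the concentration tested), compound 1 `COc1ccccc1C1C(C#N)=C(N)N(c2ccc(S(N)(=O)=O)cc2)C2=C1C(=O)CCC2` gives 0%. Compound 2 `N#CC1=C(N)N(c2ccc(S(N)(=O)=O)cc2)C2=C(C(=O)CCC2)C1c1ccc(Cl)cc1Cl` gives 40%. Compound 3 `COc1ccc2ccccc2c1C1C(C#N)=C(N)N(c2ccc(S(N)(=O)=O)cc2)C2=C1C(=O)CCC2` gives 40%.

Compound 3 sits level with compound 2 at the digits reported, and the two together hold the highest numbers of the three; the nearest neighbour is compound 2, with no change at the digits printed from compound 2 to compound 3 (within the scatter), and the furthest is compound 1, with a number 40 percentage points higher from compound 1 to compound 3 (beyond the scatter).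

Compound 4 `COc1ccc(C2C(C#N)=C(N)N(c3ccc(S(N)(=O)=O)cc3)C3=C2C(=O)CCC3)c2ccccc12` differs from compound 3 in one place: 4-methoxynaphthalen-1-yl in place of 2-methoxynaphthalen-1-yl on a saturated ring carbon. Of the measured steps, the two that bear most directly on this are a number 40 percentage points higher from compound 1 to compound 2 (beyond the scatter) and a number 40 percentage points higher from compound 1 to compound 3 (beyond the scatter), both large, and no change at the digits printed from compound 2 to compound 3 (within the scatter), where exchanging one aryl group on the saturated ring carbon for another left the number unchanged. Going by the values given here, no measured step moves the methoxy group within a naphthalenyl ring, so the closest guide is the step from compound 2 to compound 3. The expected step into compound 4 is therefore no change at the digits printed from compound 3 to compound 4 (within the scatter), none beyond the scatter. For compound 4 the estimate is 40%, between 20% and 60%.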

Compound 4, a percentage reported as activity, at one concentration (the size of the read-out at that concentration, not a potency): 10%
The estimate for compound 4 lay 30 percentage points above the measured number; measured number below the stated range.
By their numbers in this assay, from the lowest: compounds 1 and 4 (each within the scatter of the next); then compounds 2 and 3 (each within the scatter of the next).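

In this assay, the identity of the ring system and the atom count of the group do not settle the outcome at this saturated ring carbon: moving the methoxy group within the naphthalen-1-yl substituent gives a number 30 percentage points lower from compound 3 to compound 4 (beyond the scatter). The 4-methoxynaphthalen-1-yl group also falls short of the 2,4-dichlorophenyl group, with a number 30 percentage points lower from compound 2 to compound 4 (beyond the scatter), while its comparison with the 2-methoxyphenyl group gives a number 10 percentage points higher from compound 1 to compound 4 (within the scatter). No measurement available here accounts for the effect of moving the methoxy group.

Going by these compounds, it remains open how a naphthalen-1-yl group with no methoxy substituent would behave at this carbon. Also open, on these data alone, is whether a hydroxyl or an ethoxy group in place of the methoxy group would keep the same dependence on where it sits.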